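Taking the Side Chain off Compound 1

The source may report more compounds than this note shows. Statements on the series, on what has been measured and on what is new or still open speak of the compounds shown alone.

Among the compounds with values here, in a toxicity assay on HEK-293T cells (Homo sapiens) for cytotoxicity, read by MTT assay, with a stated time of 72 h (a higher number here means a weaker inhibitor, a lower number a stronger inhibitor), compound 1 (`CN1CCN(CCCCn2c3c(c4ccccc42)C(=O)c2c[n+]([O-])c4ccccc4c2C3=O)CC1`) gives 100 nM, the lower of the two numbers measured so far. Its neighbour, compound 2 (`CN1CCN(CCCCCCn2c3c(c4ccccc42)C(=O)c2c[n+]([O-])c4ccccc4c2C3=O)CC1`), gives 5800 nM. The open question concerns compound 3 (`O=C1c2c[n+]([O-])c3ccccc3c2C(=O)c2[nH]c3ccccc3c21`), which keeps the core of compound 1 but loses the whole side chain: hydrogen in place of 4-(4-methylpiperazin-1-yl)butyl on an aromatic nitrogen. In short, it carries hydrogen in place of 4-(4-methylpiperazin-1-yl)butyl on an aromatic nitrogen.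

Within the data shown here, only one measured step bears on this change, and it does so indirectly. That step, a 58-fold higher number from compound 1 to compound 2 (1.76 log units; beyond the scatter), alters the same side chain and shows that the number in this assay can move a long way with it. Among the measured compounds shown here, no compound lacking the side chain has been measured, so the size of the removal remains uncertain. A single step also makes a weak trend, but it points upward, and a large rise is expected here, though probably smaller than that step. The expected change is a 15-fold higher number from compound 1 to compound 3 (1.18 log units; beyond the scatter). For compound 3 the estimated value is 1500 nM, with an expected range from 250 nM to 9000 nM.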

Compound 3, half-maximal inhibitory concentration: 890 nM
For compound 3 the middle estimate is 1.7-fold (0.23 log units) above the measured one; low and high end bracket the measured number.
By their numbers in this assay, from the lowest: compound 1; then compound 3; then compound 2.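

Taking the side chain off altogether shows that the core of compound 1 keeps a sub-micromolar-range number of its own in this assay, with hydrogen on the aromatic nitrogen giving an 8.9-fold higher number from compound 1 to compound 3 (0.95 log units; beyond the scatter). Within the data shown here, the earlier pair showed only that the number moves with the length of the chain, whereas this step shows that the 4-(4-methylpiperazin-1-yl)butyl group goes with a lower number than hydrogen does, while the longer chain goes with a higher one: compound 3 at 890 nM stands below compound 2 at 5800 nM. So the side chain at this aromatic nitrogen can go with a number on either side of the bare core, depending on its length, and nothing at hand says why.

The compounds shown leave open whether the lower number of compound 1 follows the butyl chain or the 4-methylpiperazine at its end, a question that a plain butyl group or a butyl chain ending in morpholine would address. They also leave open where a shorter chain, such as 2-(4-methylpiperazin-1-yl)ethyl, would fall relative to compound 1 and compound 3.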